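The compounds below may be only part of what the source reports. "The series", "measured", "known", "first", "only" and "open" are said of these compounds alone.

The series shares one core, varied at a saturated ring carbon and on the aryl of the carbonyl. Compound 1 `COc1cc(-c2nnc3n2NC(c2ccco2)C(C(=O)c2ccc(F)cc2)S3)cc(OC)c1OC` gives 27700 nM in a functional assay on PC-3 cells (Homo sapiens) for cytotoxicity, read by MTT assay, with a stated time of 48 h (a lower number here means a stronger inhibitor, a higher number a weaker inhibitor), the highest of the three numbers. Compound 3 `COc1cc(-c2nnc3n2NC(c2cccs2)C(C(=O)c2ccc(F)cc2)S3)cc(OC)c1OC` gives 27400 nM, and the step of a 1.0-fold lower number from compound 1 to compound 3 (0.00 log units; within the scatter) lies within the scatter. Compound 2 `COc1cc(-c2nnc3n2NC(c2cccs2)C(C(=O)c2ccc(C)cc2)S3)cc(OC)c1OC` gives 5090 nM, and the step of a 5.4-fold higher number from compound 2 to compound 3 (0.73 log units; beyond the scatter) is the only one so far beyond the scatter.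

The step to compound 4 `COc1cc(-c2nnc3n2NC(c2ccco2)C(C(=O)c2ccc(O)cc2)S3)cc(OC)c1OC` is hydroxy in place of fluoro on an aromatic carbon. Among the compounds with values here, no measured pair shows this exchange. Within the data shown here, the only step on the aryl of the carbonyl, a 5.4-fold higher number from compound 2 to compound 3 (0.73 log units; beyond the scatter), shows that the number moved when methyl gave way to fluoro, so this part of the molecule is one where the number has moved. Whether hydroxy brings the number back toward that of compound 2 or leaves it near compound 1 cannot be read from the pairs at hand; the furan to thiophene step, a 1.0-fold lower number from compound 1 to compound 3 (0.00 log units; within the scatter), stayed within the scatter and does not bear on the aryl of the carbonyl. The expectation is therefore a small move, if any, from compound 1 to compound 4, a 1.4-fold lower number from compound 1 to compound 4 (0.14 log units; within the scatter), with a wide range. Compound 4 is expected to give about 20000 nM in this assay, between 6000 nM and 60000 nM.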

Compound 4, half-maximal inhibitory concentration: 38300 nM
Beside the measured number, compound 4's estimate is 1.9-fold (0.28 log units) below it; low and high end bracket the measured number.
By their numbers in this assay, from the lowest: compound 2; then compounds 3, 1 and 4 (each within the scatter of the next).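

In this assay, the exchange of 4-fluorophenyl for 4-hydroxyphenyl on the carbonyl gives a 1.4-fold higher number from compound 1 to compound 4 (0.14 log units; within the scatter), so adding a hydrogen-bond donor and a hydrogen-bond acceptor at this aromatic carbon leaves the number within the scatter on the furan-2-yl background. The earlier pairs shown here showed this part of the molecule only through the methyl to fluoro exchange on the thiophen-2-yl background (a 5.4-fold higher number from compound 2 to compound 3 (0.73 log units; beyond the scatter)), so the position now reads as one where not every exchange moves the number beyond the scatter, although these two steps rest on different backgrounds and the series holds just one example of each. No measurement in hand accounts for either outcome.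

From the compounds shown here alone, whether methyl keeps its lower number when furan-2-yl stands in place of thiophen-2-yl remains open, and so does whether hydroxy reads the same on the thiophen-2-yl background. Going by these compounds, it is also open whether an amine or a carboxylic acid at this aromatic carbon would side with methyl or stay with fluoro and hydroxy.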